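The source may hold more compounds than are shown below. What is called first, only, known or untested is meant among the compounds shown, and "the series" means these compounds.

Going by the values given here, in a functional assay on HL-60 cells (Homo sapiens) for antiproliferative activity, read by MTT assay, with a stated time of 72 h (a higher number here means a weaker inhibitor, a lower number a stronger inhibitor), two compounds on a shared core have numbers so far. Compound 1 (`COc1ccccc1-c1c(C(=O)c2cc(OC)c(OC)c(OC)c2)sc2ccccc12`), which carries a 2-methoxyphenyl group, gives 2900 nM. Compound 2 (`COc1cc(C(=O)c2sc3ccccc3c2Nc2ccccc2)cc(OC)c1OC`), with anilino in its place, gives 5200 nM. Among the compounds with values here, with only these two numbers to go on, compound 2 stands level with its sole neighbour, the measured step being a 1.8-fold higher number from compound 1 to compound 2 (0.25 log units; within the scatter).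

Compound 3 (`COc1ccc(Nc2c(C(=O)c3cc(OC)c(OC)c(OC)c3)sc3ccccc23)cc1`) differs from compound 2 by methoxy in place of hydrogen on an aromatic carbon, para to a large group, which turns anilino into (4-methoxyphenyl)amino: methoxy in place of hydrogen on an aromatic carbon. Within the data shown here, no measured step tests this change directly. Among the measured compounds shown here, the one step available swaps a whole group and stayed within the scatter, and compound 1, whose phenyl ring bears a methoxy, gives 2900 nM. Only a small step is therefore expected in this assay, not clearly beyond the scatter and, if anything, towards a lower number. The expected change is a 1.5-fold lower number from compound 2 to compound 3 (0.17 log units; within the scatter). For compound 3 the estimated value is 3500 nM, with an expected range from 900 nM to 12000 nM.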

Compound 3, half-maximal inhibitory concentration: 3700 nM
Estimate against measurement, compound 3: 1.1-fold (0.02 log units) below, and the stated range covers the measured number.
By their numbers in this assay, from the lowest: compounds 1, 3 and 2 (each within the scatter of the next).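

In this assay, methoxy in place of hydrogen on an aromatic carbon, para to a large group, turns anilino into (4-methoxyphenyl)amino and gives a 1.4-fold lower number from compound 2 to compound 3 (0.15 log units; within the scatter), so this first direct test of a substituent on that phenyl ring separates the two compounds by no more than the usual variation between repeated measurements. The second comparison, a 1.3-fold higher number from compound 1 to compound 3 (0.11 log units; within the scatter), shows that (4-methoxyphenyl)amino and 2-methoxyphenyl cannot be told apart here either, which means that all three groups tried at this position on the shared core give numbers within the scatter of one another. Nothing measured here offers an explanation for this flat result, and no separate data bear on it.

Going by these compounds alone, the three compounds therefore leave open whether this position can respond at all in this assay, since every step so far stays within the scatter and none sets a direction. Whether a different group on that phenyl ring, such as a hydroxy, a dimethylamino or a carboxylic acid in place of the methoxy, would give a step beyond the scatter remains unanswered.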